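Cytotoxicity Limits and a Methoxyphenyl Exchange

The source may report more compounds than this note shows. Statements on the series, on what has been measured and on what is new or still open speak of the compounds shown alone.

Compound 1, `O=C(c1ccncc1)N1N=C(c2cc3ccccc3o2)CC1c1ccccc1[N+](=O)[O-]`, in an ADME assay on Vero cells (Chlorocebus sabaeus) for cytotoxicity, read by MTT assay, with a stated time of 72 h (on this read-out lower numbers stand for stronger inhibition and higher numbers for weaker inhibition), gives only a limit, > 245000 nM.
Compound 2, `O=C(c1ccncc1)N1N=C(c2cc3ccccc3o2)CC1c1ccccc1`, in this assay gives only a limit, > 209000 nM.
Compound 3, `CCn1cc(C(=O)N2N=C(c3cc4ccccc4o3)CC2c2cccc([N+](=O)[O-])c2)c(=O)c2ccc(C)nc21`, in this assay gives only a limit, > 164000 nM.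

Compound 3 therefore stands at a limit and nowhere else on the numbers shown; it sits at the limit of > 164000 nM in this assay, at which 1 of the 3 values shown sits, while the other two compounds sit at the limit of > 209000 nM in this assay, at which 1 of the 3 values shown sits, and (the limit of > 245000 nM in this assay, at which 1 of the 3 values shown sits). For the measured compounds named here, the one step between measured compounds that differ in a single place, a step that the two limits leave unreadable from compound 1 to compound 2, is left unreadable by the two limits, so no measured step gives a readable size or direction.

Compound 4, `CCn1cc(C(=O)N2N=C(c3cc4ccccc4o3)CC2c2ccc(OC)cc2)c(=O)c2ccc(C)nc21`, differs from compound 3 by 4-methoxyphenyl in place of 3-nitrophenyl on a saturated ring carbon. Going by the values given here, no measured step bears readably on this change. The expectation is therefore that compound 4 also sits at a limit in this assay. Compound 4 is expected at about 200000 nM, between 60000 nM and 400000 nM. The step is expected to be a step that the limit leaves unreadable from compound 3 to compound 4, meaning none beyond the scatter.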

Compound 4, half-maximal inhibitory concentration: > 156000 nM
Compound 4: no number, only a limit; the forecaster's own chance of this, stated with the estimate: 80%; the middle value is on the limit's open side.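

Compound 3 and compound 4 both stand at limits, so no step can be read for 4-methoxyphenyl in place of 3-nitrophenyl. With all four values shown being limits, the compounds leave open whether any of these groups changes cytotoxicity in this assay, and by how much.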